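The source may hold more compounds than are shown below. What is called first, only, known or untested is meant among the compounds shown, and "the series" means these compounds.

Compound 1 `COc1ccc(-c2cc(=O)c3c(OC)cc(OC)cc3[nH]2)cc1`: in a functional assay on HepG2 cells (Homo sapiens) for antiproliferative activity, with a stated time of 72 h (a lower number here means that less compound is needed, a higher number that more compound is needed for the effect), compound 1 gives only a limit, > 31100 nM.
Compound 2 `COc1ccc(-c2cc(=O)c3c(OC)cc(OC)cc3n2S(=O)(=O)c2ccc(C=O)cc2)cc1`: in this assay compound 2 likewise gives only a limit, > 34400 nM.

Compound 2 thus stands at a limit of this assay, not at a number. Among the compounds with values here, the one measured step, a step that the two limits leave unreadable from compound 1 to compound 2, cannot be read in size because the limit of > 31100 nM in this assay, at which 1 of the 2 values shown sits, and the limit of > 34400 nM in this assay, at which 1 of the 2 values shown sits, are both limits. Compound 3 `COc1ccc(-c2cc(=O)c3c(OC)cc(OC)cc3n2S(=O)(=O)c2cccc([N+](=O)[O-])c2)cc1` differs from compound 2 by 3-nitrophenyl in place of 4-formylphenyl on a sulfonyl sulfur. No readable step bears on this change, so compound 3 is expected to remain at a limit as well, and the expected step that the limit leaves unreadable from compound 2 to compound 3 lies within the scatter. Compound 3 is estimated at 40000 nM, in the range 10000 nM to 120000 nM.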

Compound 3, half-maximal effective concentration: > 39600 nM
Compound 3: a limit, no number; the forecaster's own chance of this, stated with the estimate: 85%; the middle value lies beyond the limit too.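

Within the data shown here, compound 3, like compound 2, gives only a limit in this assay, so no step between these two compounds can be read. The compounds shown leave open how far any of them lies beyond its limit, and whether the sulfonyl groups change the effect at all.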